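Fluoro to trifluoromethyl: cytotoxicity on human monocyte cells

The source may hold more compounds than are shown below. What is called first, only, known or untested is meant among the compounds shown, and "the series" means these compounds.

Compound 1, `Cc1ccc(NC(=O)c2ccc3cccc(O)c3n2)cc1`: in an ADME assay on THP-1 cells (Homo sapiens) for cytotoxicity, read by WST assay, with a stated time of 24 h (a higher number here means a weaker inhibitor, a lower number a stronger inhibitor), compound 1 gives > 30000 nM, which is a limit of the assay.
Compound 2, `O=C(Nc1ccc(F)cc1)c1ccc2cccc(O)c2n1`: in this assay compound 2 gives > 30000 nM, which is also a limit.

Compound 2 thus stands at the limit of > 30000 nM in this assay, at which 2 of the 2 values shown sit. Going by the values given here, the only measured step, a step that the two limits leave unreadable from compound 1 to compound 2, cannot be read. Compound 3, `O=C(Nc1ccc(C(F)(F)F)cc1)c1ccc2cccc(O)c2n1`, differs from compound 2 by trifluoromethyl in place of fluoro on an aromatic carbon. Among the compounds with values here, no measured step gives a readable size for such a change, so in this assay no step beyond the scatter is expected. Compound 3 is therefore expected to give 30000 nM, between 10000 nM and 100000 nM. That estimate means an expected step of a number no higher from compound 2 to compound 3 (the limit leaves the size open).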

Compound 3, half-maximal inhibitory concentration: > 30000 nM
Compound 3 was reported as a limit; the forecaster's own chance of this, stated with the estimate: 85%; the middle value sits exactly at the limit.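

Going by these compounds alone, compound 1, compound 2 and compound 3 all sit at the same limit in this assay, so no step among them can be read. Whether methyl, fluoro or trifluoromethyl changes cytotoxicity at all, and at what concentration any of these compounds would harm the cells, stays open.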